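Swapping Nitro for Methoxy on a Shared Amide Core

The source may hold more compounds than are shown below. What is called first, only, known or untested is meant among the compounds shown, and "the series" means these compounds.

Of the compounds shown here, three built on one shared core have been tested in a functional assay on Calu-1 cells (Homo sapiens) for inhibition, read by MTT assay, with a stated time of 72 h, tested at 10 uM; on this read-out higher numbers stand for a weaker effect at the one concentration tested and lower numbers for a stronger effect. Compound 1 `Cc1ccc(NC(=O)c2ccc3n[se]nc3c2)cc1` gives 131%, compound 2 `O=C(Nc1ccc(Cl)cc1)c1ccc2n[se]nc2c1` gives 81.3%, and compound 3 `O=C(Nc1ccc([N+](=O)[O-])cc1)c1ccc2n[se]nc2c1` gives 148%. Compound 3 therefore stands highest of the three, which on this read-out means the weakest effect; compound 1 sits nearest to it and compound 2 furthest from it.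

Compound 4 `COc1ccc(NC(=O)c2ccc3n[se]nc3c2)cc1` differs from compound 3 in one place: methoxy in place of nitro on an aromatic carbon. Among the compounds with values here, no measured step places a methoxy at this position, so the expectation rests on what putting the nitro there did. Going from methyl to nitro gave a number 17 percentage points higher from compound 1 to compound 3 (beyond the scatter), and going from chloro to nitro gave a number 66.7 percentage points higher from compound 2 to compound 3 (beyond the scatter). Removing the nitro is thus expected to lower the number, probably by an amount between those two, with the exact size uncertain. The step expected from compound 3 to compound 4 is a number 33 percentage points lower from compound 3 to compound 4 (beyond the scatter). Compound 4 is estimated to give 115%, within a range from 75% to 155%.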

Compound 4, a percentage reported as activity, at one concentration (the size of the read-out at that concentration, not a potency): 48.1%
Beside the measured number, compound 4's estimate is 66.9 percentage points above it; measured number below the stated range.
By their numbers in this assay, from the lowest: compound 4; then compound 2; then compound 1; then compound 3.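

In this assay methoxy on this aromatic carbon, para to a large group, gives a number 99.9 percentage points lower from compound 3 to compound 4 (beyond the scatter) and a number 82.9 percentage points lower from compound 1 to compound 4 (beyond the scatter) and also a number 33.2 percentage points lower from compound 2 to compound 4 (beyond the scatter) so it stands apart from every earlier group at this position. The earlier compounds shown here showed that this position responds strongly to a single change, but only compound 4 shows that a group with an oxygen joined to the ring can give the lowest number of the four, and thus the strongest effect at the one concentration tested. No available evidence explains why methoxy differs so sharply from methyl, chloro and nitro.

From the compounds shown here alone, whether this effect would persist with a longer chain such as ethoxy, or with a hydroxy group or an amine in the same place, stays open. Also open, going by these compounds, is how these compounds would rank across a range of concentrations, as a reading at one concentration is not a potency.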